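The source may hold more compounds than are shown below. What is called first, only, known or untested is meant among the compounds shown, and "the series" means these compounds.

Compound 1 `C#CCN(Cc1ccccc1)Cc1cc2ccccc2n1C` is tested in an assay on isolated protein for inhibition of Amine oxidase [flavin-containing] B (Rattus norvegicus) (on this read-out higher numbers stand for weaker inhibition and lower numbers for stronger inhibition), where compound 1 gives 60000 nM. Among the three compounds with numbers, that is the highest. Compound 3 `CC#CCNCc1cc2cc(OCc3ccccc3)ccc2[nH]1` gives 15 nM in this assay, and compound 2 `C#CCNCc1cc2cc(OC)ccc2n1C` gives 4 nM; both stand far below compound 1, well beyond the scatter, so compound 1 is the weakest inhibitor of the three. Compound 2 and compound 3 both lack the benzyl group that compound 1 carries on its amine nitrogen, though they also differ from compound 1 elsewhere on the shared core and at the nitrogen itself.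

Compound 4 `C#CCN(C)Cc1cc2ccccc2n1C` has not yet been measured. It differs from compound 1 in one place: hydrogen in place of phenyl on a saturated chain carbon bound to an amine nitrogen. Among the compounds with values here, no pair of measured compounds differs by exactly this change, so no directly comparable step exists. What the numbers do show is that the two measured compounds without the benzyl group, compound 2 and compound 3, sit far lower than compound 1. On that basis the expected step is a 600-fold lower number from compound 1 to compound 4 (2.78 log units; beyond the scatter), downward and well beyond the scatter. Compound 4 is accordingly estimated to give about 100 nM in this assay, with a range from 10 nM to 2000 nM.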

Compound 4, inhibition constant: 3 nM
Beside the measured number, compound 4's estimate is 33-fold (1.52 log units) above it, outside the stated range (below it).
By their numbers in this assay, from the lowest: compounds 4 and 2 (each within the scatter of the next); then compound 3; then compound 1.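

With hydrogen in place of phenyl on a saturated chain carbon bound to an amine nitrogen, which is the same as benzyl to methyl, this assay gives a 20000-fold lower number from compound 1 to compound 4 (4.30 log units; beyond the scatter) with nothing else on the molecule altered. Within the data shown here, this is the first comparison in the set that tests this change on its own, since compound 2 and compound 3 each differ from compound 1 in more than one place and could not separate the phenyl from the other differences. It shows that this single position can carry a very large change in the number on the shared core of compound 1, and no measurement shown here explains why the step is so large.

The compounds shown cover only phenyl and hydrogen at this carbon, so it remains open how the number responds to a group such as methyl, ethyl or cyclopropyl there, or to a phenyl ring bearing a fluorine or a methoxy group. As far as these compounds go, it is also open whether the same change gives a step of similar size on a core that carries a methoxy or benzyloxy group.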